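This account rests on a few compounds, and the source may have more. Where it says the series, first, only, none or still open, it means among the compounds named here.

Compound 1 `CCN(CC)c1ccc(-c2cccc(C(F)(F)F)c2)nn1`, compound 2 `CN1CCN(c2ccc(-c3cccc(C(F)(F)F)c3)nn2)CC1` and compound 3 `FC(F)(F)c1cccc(-c2ccc(N3CCCC3)nn2)c1` share one core and differ only in the group on an aromatic carbon. In an ADME assay on HaCaT cells (Homo sapiens) for antiproliferative activity, with a stated time of 48 h (a lower number here means a stronger inhibitor, a higher number a weaker inhibitor), compound 1 gives > 25000 nM, which is a limit. Compound 2 gives > 25000 nM, also a limit. Compound 3 gives > 25000 nM, again a limit, so it has no number of its own. All three stand at the limit of > 25000 nM in this assay, at which 3 of the 3 values shown sit.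

Compound 4 `FC(F)(F)c1cccc(-c2ccc(Oc3ccccc3)nn2)c1` carries this change: phenoxy in place of pyrrolidin-1-yl on an aromatic carbon. The nearest measured evidence is a step that the two limits leave unreadable from compound 1 to compound 3 and a step that the two limits leave unreadable from compound 2 to compound 3, along with a step that the two limits leave unreadable from compound 1 to compound 2. Among the measured compounds shown here, none of these gives a size to carry over, and no measured compound holds phenoxy. The expected change is an at least 1.1-fold lower number from compound 3 to compound 4 (0.05 log units; that floor lies within the scatter), small and, if readable at all, towards a stronger inhibitor. Compound 4 is estimated at 22000 nM, with an expected range of 8000 nM to 40000 nM.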

Compound 4, half-maximal inhibitory concentration: > 25000 nM
Compound 4: only a limit was reported (the forecaster's own chance of this, stated with the estimate: 65%); middle value at least 1.1-fold (0.05 log units) from the limit.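

Among the compounds shown here, compound 4 also gives only a limit, so no step from compound 1, compound 2 or compound 3 to compound 4 can be read: the limit of > 25000 nM in this assay, at which 4 of the 4 values shown sit. The compounds shown leave open whether any group on this aromatic carbon gives a readable value.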